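This account rests on a few compounds, and the source may have more. Where it says the series, first, only, none or still open, it means among the compounds named here.

Measured compounds:
compound 1 `N=C1S/C(=C\c2ccc(OCc3ccccc3)cc2)C(=O)N1c1ccc(Cl)cc1` — 16.4%
compound 2 `Cc1cccc(N2C(=N)S/C(=C\c3ccc(OCc4ccccc4)cc3)C2=O)n1` — 25.1%
compound 3 `N=C1S/C(=C\c2ccc(OCc3ccccc3)cc2)C(=O)N1c1ccccc1` — 37.9%

In an ADME assay on RAW264.7 cells (Mus musculus) for cytotoxicity, read by MTT assay, with a stated time of 48 h, tested at 50 uM (a higher number here means more inhibition at the concentration tested (going by the name of the read-out), a lower number less inhibition), compound 3 stands highest of the three numbers. Compound 2 is nearest, and the step of a number 12.8 percentage points higher from compound 2 to compound 3 (beyond the scatter) lies beyond the scatter; compound 1 is furthest, and the step of a number 21.5 percentage points higher from compound 1 to compound 3 (beyond the scatter) also lies beyond the scatter. The step of a number 8.7 percentage points higher from compound 1 to compound 2 (within the scatter) stays within the scatter.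

Compound 4 `Cc1ccc(C)c(N2C(=N)S/C(=C\c3ccc(OCc4ccccc4)cc3)C2=O)c1` is not yet measured. It differs from compound 3 in one place: 2,5-dimethylphenyl in place of phenyl on an amide-type nitrogen in a ring

Within the data shown here, two measured steps bear on this change. The step of a number 21.5 percentage points higher from compound 1 to compound 3 (beyond the scatter) shows that removing a substituent from the aryl group on the amide-type nitrogen in the ring raised inhibition modestly; compound 4 goes the other way, adding two methyl groups to that aryl ring, so a drop of similar size is one possibility. The step of a number 12.8 percentage points higher from compound 2 to compound 3 (beyond the scatter) shows that a different aryl group on that nitrogen, carrying one methyl, sat modestly lower than phenyl. Neither step is a true precedent for a dimethylphenyl, so the size is uncertain.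

On this basis a modest decrease is expected, a number 10.9 percentage points lower from compound 3 to compound 4 (beyond the scatter), though a result within the scatter cannot be excluded. The estimate for compound 4 is 27%, with a range from 12% to 44%.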

Compound 4, a percentage reported as inhibition, at one concentration (the size of the read-out at that concentration, not a potency): 45.8%
Estimate against measurement, compound 4: 18.8 percentage points below, outside the stated range (above it).
By their numbers in this assay, from the lowest: compounds 1 and 2 (each within the scatter of the next); then compounds 3 and 4 (each within the scatter of the next).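

Among these compounds, at the amide-type nitrogen in the ring, in this assay, 2,5-dimethylphenyl in place of phenyl gives a number 7.9 percentage points higher from compound 3 to compound 4 (within the scatter), so adding two methyl groups to this aryl ring produces no step that can be told from the scatter, and the drop that the chloro step left open does not appear. The same group stands well clear of the other two aryl groups at this position, with a number 20.7 percentage points higher from compound 2 to compound 4 (beyond the scatter) and a number 29.4 percentage points higher from compound 1 to compound 4 (beyond the scatter); the series thus splits into a pair of phenyl and 2,5-dimethylphenyl and a lower pair of 4-chlorophenyl and 6-methylpyridin-2-yl, so a substituent on this aryl ring does not by itself lower the number, as compound 4 shows against compound 1. No data here offer an explanation for this split.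

The compounds shown leave open how a carboxylic acid or an amine on this aryl ring, or a benzyl group or longer alkyl chain in place of it, would read in this assay. They also leave open whether a single methyl group on the phenyl ring reads with the upper pair.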